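Fluoro Gives Way to Methoxy: What to Expect

The compounds below may be only part of what the source reports. "The series", "measured", "known", "first", "only" and "open" are said of these compounds alone.

In a functional assay on HCT-116 cells (Homo sapiens) for cytotoxicity, read by sulforhodamine B assay, with a stated time of 48 h (on this read-out higher numbers stand for weaker inhibition and lower numbers for stronger inhibition), compound 1 `O=C(Nc1n[nH]c2c1CN(C(=O)c1ccccc1)C2)c1ccccc1` reads 6400 nM while compound 2 `O=C(Nc1n[nH]c2c1CN(C(=O)c1ccccc1)C2)c1ccc(F)cc1` reads 3190 nM on the same scale. These two values lie within the usual scatter of each other, so on the numbers available compound 2 cannot be told apart from compound 1.

Going from compound 2 to compound 3 `COc1ccc(C(=O)Nc2n[nH]c3c2CN(C(=O)c2ccccc2)C3)cc1` the change is methoxy in place of fluoro on an aromatic carbon and in words it is methoxy in place of fluoro on an aromatic carbon, para to a large group. Among the measured compounds shown here, no measured compound carries methoxy. For the measured compounds named here, the one measured step, a 2.0-fold lower number from compound 1 to compound 2 (0.30 log units; within the scatter) for fluoro in place of hydrogen on an aromatic carbon, stayed within the scatter and offers only a weak guide. With so little to go on, no shift beyond the scatter is expected in this assay in either direction. The estimated step is a 1.3-fold higher number from compound 2 to compound 3 (0.10 log units; within the scatter) and it remains only an expectation. Compound 3 is expected at 4000 nM within an estimated range of 1500 nM to 10000 nM for now.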

Compound 3, half-maximal inhibitory concentration: 13600 nM
For compound 3 the middle estimate is 3.4-fold (0.53 log units) below the measured one, outside the stated range (above it).
By their numbers in this assay, from the lowest: compounds 2 and 1 (each within the scatter of the next); then compound 3.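

In this assay the swap of fluoro for methoxy on this aromatic carbon, para to a large group, gives a 4.3-fold higher number from compound 2 to compound 3 (0.63 log units; beyond the scatter) and so provides the first clear sign that the position responds to what sits on it. The comparison with the hydrogen-bearing compound points the same way, since methoxy in place of hydrogen gives a 2.1-fold higher number from compound 1 to compound 3 (0.33 log units; beyond the scatter) and so methoxy stands apart from both hydrogen and fluoro, on the side of weaker inhibition, although that gap from hydrogen is only modest. Nothing at hand explains why methoxy behaves this way.

The compounds shown leave open whether the oxygen or the added carbon of methoxy matters more, a question that a methyl or hydroxyl group on the same carbon could help to separate. They also leave open whether a longer chain such as ethoxy would move the number further in the same direction, or whether the change seen here is specific to methoxy.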